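The compounds below may be only part of what the source reports. "The series", "measured", "known", "first", "only" and "open" are said of these compounds alone.

Measured so far in a functional assay (trachea) for inhibition, with Cavia porcellus as the target; on this read-out higher numbers stand for weaker inhibition and lower numbers for stronger inhibition
compound 1 `CC1(C)c2ccc(I)cc2[C@@H](N2CCCCC2=O)[C@@H]1O` gives 300 nM
compound 2 `CC1(C)C=C(N2CCCCC2=O)c2cc([N+](=O)[O-])ccc21` gives 2240 nM

Compound 2 has the higher of the two numbers at 2240 nM and lies beyond the scatter from compound 1. Compound 3 `CC1(C)C=C(n2ccccc2=O)c2cc([N+](=O)[O-])ccc21` differs from compound 2 in one place as a group of 7 heavy atoms (5 carbon, 1 nitrogen, 1 oxygen; one six-membered aromatic ring with 1 hetero atom) in place of a group of 7 heavy atoms (5 carbon, 1 nitrogen, 1 oxygen; one six-membered non-aromatic ring with 1 hetero atom), on a double-bonded ring carbon and is otherwise the same. For the measured compounds named here, no measured pair isolates this change, so on judgment alone a moderate step to a lower number, meaning stronger inhibition, is expected in this assay for this swap. The expected size is a 2.8-fold lower number from compound 2 to compound 3 (0.45 log units; beyond the scatter) on this estimate. Compound 3 is estimated at 800 nM with 150 nM to 3500 nM as the expected range.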

Compound 3, half-maximal inhibitory concentration: 840 nM
Estimate against measurement, compound 3: 1.1-fold (0.02 log units) below; measured number inside the range.
By their numbers in this assay, from the lowest: compound 1; then compound 3; then compound 2.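

In this assay, putting a six-membered aromatic ring with one hetero atom in place of 2-oxopiperidin-1-yl on the double-bonded ring carbon gives a 2.7-fold lower number from compound 2 to compound 3 (0.43 log units; beyond the scatter) as a modest step beyond the scatter. This first one-place pair shows that the number at this position responds to the ring changing from non-aromatic to aromatic, with the heavy-atom count unchanged. No available data explain this step.

Other groups at this position remain open, such as an open-chain acetamide or a pyrrolidin-2-one. From the compounds shown here alone, it is also open whether the same swap gives a similar step with a nitrile in place of the nitro group.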